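The compounds below may be only part of what the source reports. "The series", "measured", "known", "first", "only" and "open" are said of these compounds alone.

Measured so far:
compound 1, `O=C(N/N=C/c1ccccc1Cl)c1cnccn1` — 70%
compound 2, `COc1ccccc1/C=N/NC(=O)c1cnccn1` — 97%

In an ADME assay on J774 cells (Mus musculus) for cytotoxicity, read by MTT assay, with a stated time of 48 h, tested at 50 ug/mL (on this read-out higher numbers stand for a weaker effect at the one concentration tested and lower numbers for a stronger effect), compound 2 gives the higher of the two numbers. For the measured compounds named here, the only measured step is a number 27 percentage points higher from compound 1 to compound 2 (beyond the scatter), which came with methoxy in place of chloro on an aromatic carbon; because of that step, compound 2 stands clearly above compound 1.

Compound 3, `N#Cc1ccccc1/C=N/NC(=O)c1cnccn1`, has not yet been measured. Compared with compound 2 it shows (cyano in place of methoxy on an aromatic carbon). Going by the values given here, the one known step concerns a methoxy group entering, not a cyano group, so it bears on the new change only by showing that swapping the group at this place can move the number well beyond the scatter. Among the compounds with values here, with no step that involves cyano, the change from compound 2 to compound 3 is expected to be a number 12 percentage points lower from compound 2 to compound 3 (beyond the scatter), a step that may or may not exceed the scatter. Compound 3 is therefore estimated at 85%, within a range from 62% to 100%.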

Compound 3, a percentage reported as activity, at one concentration (the size of the read-out at that concentration, not a potency): 92%
Compound 3: the middle estimate sits 7 percentage points below what was measured; measured number inside the range.
By their numbers in this assay, from the lowest: compound 1; then compounds 3 and 2 (each within the scatter of the next).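

In this assay, cyano in place of methoxy on the aromatic carbon gives a number 5 percentage points lower from compound 2 to compound 3 (within the scatter), so the two groups cannot be told apart at this position, even though cyano brings a triple bond and a nitrogen in place of methoxy's oxygen. Cyano in place of chloro gives a number 22 percentage points higher from compound 1 to compound 3 (beyond the scatter), so the gap from chloro now appears with a second group, and among these three compounds only compound 1 stands apart. Nothing available here explains why chloro differs from the other two groups.

From the compounds shown here alone, it remains open whether an amine, a carboxylic acid or a longer chain at this position would sit with methoxy and cyano or with chloro. A single concentration also leaves open how these compounds would compare at other doses.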